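Oxazole attachment point and tolerated concentration in the series

A few compounds are considered here, and "the series" means these few. Any claim that something is new, unique, unknown or untested is made for them only; others in the source may bear on it.

Within the data shown here, compound 1 `O=C1CC(c2cnco2)CN1c1cnn2c1CN(C(=O)Nc1cc(F)c(F)c(F)c1)C(C1CC1)C2` is the one member of the pair that returns a number in a toxicity assay on HepG2 2.2.15 cells (Homo sapiens) for cytotoxicity, read by CellTiter-Glo (a lower number here means that less compound is tolerated, a higher number that more compound is tolerated), rather than a limit: in this assay compound 1 gives 139000 nM. Compound 2 `CC1(C)CN(C(=O)Nc2cc(F)c(F)c(F)c2)Cc2c(N3CC(C#N)CC3=O)cnn21` sits at the upper limit of the assay; in this assay compound 2 gives > 200000 nM, which is a limit and not a number. Across the two values shown, one of the two sits at that limit: the limit of > 200000 nM in this assay, at which 1 of the 2 values shown sits. Among the measured compounds shown here, no step between measured compounds that differ in one place is available, so compound 1 and compound 2 together say only that both are tolerated at high concentration.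

Compound 3 `O=C1CC(c2ncco2)CN1c1cnn2c1CN(C(=O)Nc1cc(F)c(F)c(F)c1)C(C1CC1)C2` differs from compound 1 in one place. 1,3-oxazol-2-yl in place of 1,3-oxazol-5-yl on a saturated ring carbon The group that leaves and the group that enters have the same atoms, joined differently, on a saturated ring carbon of a five-membered non-aromatic ring with one nitrogen.

For the measured compounds named here, for this assay the expected step of a 1.1-fold higher number from compound 1 to compound 3 (0.03 log units; within the scatter) is none beyond the usual scatter, since the measured series gives no step of this kind to build on. Compound 3 is therefore expected to give about 150000 nM in this assay, with a range from 70000 nM to 300000 nM.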

Compound 3, half-maximal cytotoxic concentration: > 200000 nM
Compound 3 ended at the assay's limit; the forecaster's own chance of this, stated with the estimate: 35%; middle value at least 1.3-fold (0.12 log units) from the limit.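

Placing 1,3-oxazol-2-yl in place of 1,3-oxazol-5-yl on this saturated ring carbon gives the first step in the series between compounds that differ in one place: in this assay, the change reads as an at least 1.4-fold higher number from compound 1 to compound 3 (0.15 log units; that floor lies within the scatter). Among these compounds, this step is a floor and not a size, and since the floor lies within the scatter, it sets no order between the two attachment points; it shows only that this swap of same-atom groups brings no visible drop in the tolerated concentration at this position. The limit now governs how far the series can be read, and further changes that leave the number high will give no measurable size: the limit of > 200000 nM in this assay, at which 2 of the 3 values shown sit.

On these data alone, how far past the limit compound 3 lies remains open, so the real size of the step from the 1,3-oxazol-5-yl group to the 1,3-oxazol-2-yl group is unknown. Also open, as far as these compounds go, is whether a different kind of group on the same saturated ring carbon, such as an amine or a carboxylic acid, would bring the number down to a value that can be read in this assay.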